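A few compounds are considered here, and "the series" means these few. Any claim that something is new, unique, unknown or untested is made for them only; others in the source may bear on it.

Compound 1, `C[C@@H](/N=C(\S)NCc1ccc(C(C)(C)C)cc1)c1ccc(C(C)(C)C)cc1` — in a functional assay with Rattus norvegicus as the target (on this read-out lower numbers stand for an effect already at smaller amounts and higher numbers for an effect only at larger amounts of compound), compound 1 gives > 100000 nM, a limit of the assay.
Compound 2, `C[C@H](/N=C(\S)NCc1ccc(C(C)(C)C)cc1)c1ccc([N+](=O)[O-])cc1` — in this assay compound 2 gives > 100000 nM, also a limit.
Compound 3, `CC(C)C(/N=C(\S)NCc1ccc(C(C)(C)C)cc1)c1ccc(NS(C)(=O)=O)cc1` — in this assay compound 3 gives > 100000 nM, again a limit.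

Compound 1 therefore stands where every measured compound stands: at the limit of > 100000 nM in this assay, at which 3 of the 3 values shown sit. Among the measured compounds shown here, no value with a number exists for any of them, so no measured step can be sized here. Compound 4, `C[C@@H](/N=C(\S)NCc1ccc(C(C)(C)C)cc1)c1ccccc1`, is the next compound to be tested. It differs from compound 1 by hydrogen in place of tert-butyl on an aromatic carbon. With all three values sitting at the limit, the account expects compound 4 to remain at or near that limit, and the step that the limit leaves unreadable from compound 1 to compound 4 is expected to be none beyond the scatter. For compound 4 the estimate is 150000 nM, within a range from 30000 nM to 1000000 nM.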

Compound 4, half-maximal effective concentration: > 100000 nM
Compound 4 ended at the assay's limit; the forecaster's own chance of this, stated with the estimate: 85%; the middle value does not contradict the limit.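

Compound 1 and compound 4 both sit at a limit of the assay, so no step between them can be read: the limit of > 100000 nM in this assay, at which 4 of the 4 values shown sit.

The compounds shown leave open whether hydrogen in place of tert-butyl changes anything in this assay, and which compound, if any, would give a numbered value there.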